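Pyridin-2-yl for phenyl on the triazole of compound 2

This account rests on a few compounds, and the source may have more. Where it says the series, first, only, none or still open, it means among the compounds named here.

Going by the values given here, compound 2 `O=C(NO)c1ccc(NCc2nc(-c3ccccc3)nn2-c2ccccc2)cc1` stands highest of the two numbers measured so far: in an assay on Sf9 cells for inhibition of protein deacetylase HDAC6 (Homo sapiens), read by fluorescence, with a stated time of 40 min, tested at 100 nM (on this read-out lower numbers stand for less inhibition and higher numbers for more inhibition at the one concentration tested (going by the name of the read-out)), compound 2 gives 72.6%. Among the compounds with values here, its only neighbour, compound 1 `O=C(NO)c1ccc(NCc2nc(-c3cccnc3)nn2-c2ccccc2)cc1`, gives 57.7% in this assay, and the single measured step, a number 14.9 percentage points higher from compound 1 to compound 2 (beyond the scatter), shows what replacing a ring nitrogen-bearing six-membered ring with a plain phenyl did at this position.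

Compound 3 `O=C(NO)c1ccc(NCc2nc(-c3ccccn3)nn2-c2ccccc2)cc1` is the next candidate. The change from compound 2 is pyridin-2-yl in place of phenyl on an aromatic carbon. Within the data shown here, this is the mirror of the one measured step, though the ring nitrogen now sits in a different place in the entering group. Since that step rose by a modest margin when the pyridine nitrogen was removed, the return of a ring nitrogen is expected to give back part or all of that gain, so a downward step of moderate size is expected here rather than none beyond the scatter. Compound 3 is therefore estimated to give 60% in this assay, within a range of 45% to 75%. This corresponds to an expected step of a number 12.6 percentage points lower from compound 2 to compound 3 (beyond the scatter).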

Compound 3, a percentage reported as inhibition, at one concentration (the size of the read-out at that concentration, not a potency): 58.6%
The estimate for compound 3 lay 1.4 percentage points above the measured number, within the range that was stated.
By their numbers in this assay, from the lowest: compounds 1 and 3 (each within the scatter of the next); then compound 2.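

In this assay, the exchange of phenyl for pyridin-2-yl on this aromatic carbon of the five-membered ring gives a number 14 percentage points lower from compound 2 to compound 3 (beyond the scatter), so the drop is no longer tied to pyridin-3-yl alone. The two pyridine compounds cannot be told apart, with a number 0.9 percentage points higher from compound 1 to compound 3 (within the scatter), which means that the place of the ring nitrogen within the group makes no readable difference between these two; among the three compounds, both rings that carry a nitrogen stand apart from the all-carbon phenyl of compound 2, and none goes against this. Nothing available explains why the ring nitrogen goes with the lower number here.

Going by these compounds, it remains open whether pyridin-4-yl would fall with the two pyridine groups, and whether a phenyl ring carrying a methoxy group or a fluorine atom would hold the number of compound 2 or move it. The numbers also come from a single concentration, so they leave open whether the same order would hold in a full measure of potency.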